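A few compounds are considered here, and "the series" means these few. Any claim that something is new, unique, unknown or untested is made for them only; others in the source may bear on it.

Working notes on the series

Three measured compounds share one core. Compound 1 `Cc1c(C(=O)Nc2c(F)cc(-c3cccc(F)c3)cc2F)nc2ccc(F)cc2c1O` carries fluoro and hydroxy on the core; compound 2 `CCOc1ccc2nc(C(=O)Nc3c(F)cc(-c4cccc(F)c4)cc3F)c(C)c(O)c2c1` and compound 3 `Cc1c(C(=O)Nc2c(F)cc(-c3cccc(F)c3)cc2F)nc2ccc(F)cc2c1C(=O)O` each change one of these. In a functional assay on A-375 cells (Homo sapiens) for antiproliferative activity, read by MTT assay, with a stated time of 24 h, tested at 0.05 ug/mL (a higher number here means a stronger effect of the compound at the concentration tested, a lower number a weaker effect), compound 1 gives 0.05%. In this assay compound 2 gives 1.02% and compound 3 gives 0.37%. The change ethoxy in place of fluoro on an aromatic carbon produces a number 1 percentage points higher from compound 1 to compound 2 (within the scatter). The change carboxy in place of hydroxy on an aromatic carbon produces a number 0.3 percentage points higher from compound 1 to compound 3 (within the scatter). All three read-outs lie within the scatter of one another, so no order among them is claimed.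

Compound 4 `CCOc1ccc2nc(C(=O)Nc3c(F)cc(-c4cccc(F)c4)cc3F)c(C)c(C(=O)O)c2c1` is not yet measured. It differs from compound 3 by ethoxy in place of fluoro on an aromatic carbon, the same change that leads from compound 1 to compound 2, made here on a core that differs from that of compound 1 by the carboxy in place of hydroxy change described above. For this assay the step is expected to be a number 0.9 percentage points higher from compound 3 to compound 4 (within the scatter), which rests on a number 1 percentage points higher from compound 1 to compound 2 (within the scatter) being within the scatter. Compound 4 is therefore estimated to give 1.3% in this assay, expected between 0% and 8%.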

Compound 4, a percentage reported as inhibition, at one concentration (the size of the read-out at that concentration, not a potency): 1.96%
Estimate against measurement, compound 4: 0.7 percentage points below; the measured number falls inside the stated range.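

Carried to the core of compound 3 in this assay, ethoxy in place of fluoro on an aromatic carbon gives a number 1.6 percentage points higher from compound 3 to compound 4 (within the scatter) and so reads the same as on the core of compound 1: the same change on two cores in this assay, a number 1 percentage points higher (within the scatter) from compound 1 to compound 2 and a number 1.6 percentage points higher (within the scatter) from compound 3 to compound 4, 0.6 percentage points apart, within the scatter of two such steps.

Carboxy in place of hydroxy on an aromatic carbon gives a number 0.9 percentage points higher from compound 2 to compound 4 (within the scatter) and likewise shows no difference between the two cores: the same change on two cores in this assay, a number 0.3 percentage points higher (within the scatter) from compound 1 to compound 3 and a number 0.9 percentage points higher (within the scatter) from compound 2 to compound 4, 0.6 percentage points apart, within the scatter of two such steps.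

Neither change therefore shows any dependence on the core, but with every step inside the scatter, this does not show that either change has a real effect in this assay or that the steps add up in a dependable way.

The compounds shown leave open whether any replacement at these two places would give a read-out clearly beyond the scatter, for instance an amine or a longer alkoxy chain such as butoxy on the aromatic carbon now carrying ethoxy. With a single tested concentration, they also leave open how strong an effect any of the compounds would have at another concentration.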